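The compounds below may be only part of what the source reports. "The series", "measured", "known", "first", "only" and "open" are said of these compounds alone.

Compound 3 `CN(C)CCn1cnnc1-c1cc(Oc2ccc(NC(=O)N/N=C/c3ccc(O)c(O)c3)cc2F)ccn1` stands at the weak end of the three measured compounds. In a functional assay on U-87MG ATCC cells (Homo sapiens) for cytotoxicity, read by MTT assay, with a stated time of 72 h (a higher number here means a weaker inhibitor, a lower number a stronger inhibitor), compound 3 reaches only the limit of the assay, > 100000 nM, which is a limit and not a number, as the limit of > 100000 nM in this assay, at which 1 of the 3 values shown sits, records. The other two sit inside the measurable range: compound 1 `COc1ccc(OC)c(/C=N/NC(=O)Nc2ccc(Oc3ccnc(-c4nncn4CCN(C)C)c3)c(F)c2)c1` gives 6400 nM in this assay, and compound 2 `CN(C)CCn1cnnc1-c1cc(Oc2ccc(NC(=O)N/N=C/c3ccccc3)cc2F)ccn1` gives 2250 nM, so that a 2.8-fold lower number from compound 1 to compound 2 (0.45 log units; beyond the scatter). Compound 4 `CN(C)CCn1cnnc1-c1cc(Oc2ccc(NC(=O)N/N=C/c3ccc(Cl)cc3)cc2F)ccn1` differs from compound 3 by 4-chlorophenyl in place of 3,4-dihydroxyphenyl on a carbon with a double bond to nitrogen. For the measured compounds named here, the steps that bear on this change are the two that brought the 3,4-dihydroxyphenyl in: an at least 15-fold higher number from compound 1 to compound 3 (1.19 log units; beyond the scatter), and an at least 44-fold higher number from compound 2 to compound 3 (1.64 log units; beyond the scatter). Compound 4 removes that group again, and the expected move is a large fall in the number, an at least 40-fold lower number from compound 3 to compound 4 (1.60 log units; beyond the scatter), back toward the region where compound 2 sits. Compound 4 is therefore expected to give about 2500 nM in this assay, within an estimated range from 800 nM to 8000 nM.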

Compound 4, half-maximal inhibitory concentration: 1370 nM
Estimate against measurement, compound 4: 1.8-fold (0.26 log units) above; measured number inside the range.
By their numbers in this assay, from the lowest: compounds 4 and 2 (each within the scatter of the next); then compound 1. At a limit, above all of these: compound 3.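

With 4-chlorophenyl in place of 3,4-dihydroxyphenyl on a carbon with a double bond to nitrogen, this assay records an at least 72-fold lower number from compound 3 to compound 4 (1.86 log units; beyond the scatter), which shows that a substituent on the phenyl does not by itself bring the number up to the level of compound 3. The value of compound 3 in this step is a limit and not a number: the limit of > 100000 nM in this assay, at which 1 of the 4 values shown sits. Chloro in place of hydrogen on an aromatic carbon gives a 1.6-fold lower number from compound 2 to compound 4 (0.22 log units; within the scatter), and 4-chlorophenyl in place of 2,5-dimethoxyphenyl gives a 4.7-fold lower number from compound 1 to compound 4 (0.67 log units; beyond the scatter), so the chloro group leaves the number in the range of the unsubstituted phenyl.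

The compounds shown leave open whether both hydroxyl groups of the 3,4-dihydroxyphenyl are needed for the rise in the number or a single hydroxyl would be enough. They also leave open how an amine or a carboxylic acid on this phenyl would read in this assay.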